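Swapping One Carbonyl Substituent in a Growth Inhibitor

A few compounds are considered here, and "the series" means these few. Any claim that something is new, unique, unknown or untested is made for them only; others in the source may bear on it.

In a functional assay on HepG2 cells (Homo sapiens) for inhibition, read by MTT assay, with a stated time of 24 h (on this read-out lower numbers stand for stronger inhibition of growth and higher numbers for weaker inhibition of growth), compound 1 `Cn1cc(-c2nc3ccccc3n2C(=O)c2cccc(Br)c2)c2ccccc21` gives 61400 nM, while compound 2 `COc1ccc(C(=O)n2c(-c3cn(C)c4ccc(OC)cc34)nc3ccccc32)cc1` gives 12800 nM, the lower of the two numbers and so the stronger inhibition of growth. Compound 3 `COc1ccc2c(c1)c(-c1nc3ccccc3n1C(=O)c1cccc(Br)c1)cn2C` has not yet been measured. It differs from compound 2 by one change: 3-bromophenyl in place of 4-methoxyphenyl on a carbonyl carbon, with 3-bromophenyl in place of 4-methoxyphenyl on a carbonyl carbon. For the measured compounds named here, no measured pair isolates this change, so the direction is a judgement: a moderate rise in this assay, meaning weaker inhibition. The estimated change is a 2.2-fold higher number from compound 2 to compound 3 (0.34 log units; beyond the scatter). Compound 3 is expected at 28000 nM, with an estimated range of 11000 nM to 65000 nM.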

Compound 3, concentration for 50% growth inhibition: 51300 nM
Estimate against measurement, compound 3: 1.8-fold (0.26 log units) below; the range from low to high includes it.
By their numbers in this assay, from the lowest: compound 2; then compounds 3 and 1 (each within the scatter of the next).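

In this assay, 3-bromophenyl in place of 4-methoxyphenyl on the carbonyl carbon gives a 4.0-fold higher number from compound 2 to compound 3 (0.60 log units; beyond the scatter), so this position does affect growth inhibition when the core carries its methoxy. With 3-bromophenyl on the carbonyl, methoxy in place of hydrogen on an aromatic carbon of the core gives a 1.2-fold lower number from compound 1 to compound 3 (0.08 log units; within the scatter), which shows no clear effect. No measurement here explains the difference between these two groups. The compounds shown leave open whether 4-methoxyphenyl has the same effect on the core without methoxy, and how an amine or a carboxylic acid on the phenyl ring would compare.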